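The source may hold more compounds than are shown below. What is called first, only, known or untested is meant among the compounds shown, and "the series" means these compounds.

Measured so far in a functional assay on Maver1 cells (Homo sapiens) for inhibition, read by luminescence and CellTiter-Glo, with a stated time of 72 h; a lower number here means a stronger inhibitor, a higher number a weaker inhibitor:

Compound 1, `C/C=C/C(=O)Nc1ccc(Cn2nc(-c3ccc(Oc4ccccc4)cc3)cc2CO)cc1`: 48400 nM
Compound 2, `C/C=C/C(=O)Nc1cccc(Cn2nc(-c3ccc(Oc4ccccc4)cc3)cc2C(=O)OCC)c1`: 14200 nM
Compound 3, `C=CC(=O)Nc1cccc(Cn2nc(-c3ccc(Oc4ccccc4)cc3)cc2C(=O)OCC)c1`: 8600 nM

Compound 1 gives the highest of the three numbers; its cores differ from those of compound 2 and compound 3, and the difference between the two cores is not broken down here. Compound 2 and compound 3 share a core and differ only at one point, (vinyl in place of prop-1-en-1-yl on a carbonyl carbon), which gave a 1.7-fold lower number from compound 2 to compound 3 (0.22 log units; within the scatter).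

Compound 4, `C=CC(=O)Nc1ccc(Cn2nc(-c3ccc(Oc4ccccc4)cc3)cc2CO)cc1`, has not yet been measured. It differs from compound 1 by vinyl in place of prop-1-en-1-yl on a carbonyl carbon, the same change that was made from compound 2 to compound 3, on the same kind of carbonyl carbon with an amide-type nitrogen as its other neighbour. This change occurs twice among the compounds shown, and only one instance is measured, so the expectation rests on a single precedent on a different core.

Compound 4 is expected to give 28000 nM in this assay, within 12000 nM to 65000 nM, that is an expected 1.7-fold lower number from compound 1 to compound 4 (0.24 log units; within the scatter), of about the same size as the measured step, because the precedent is a 1.7-fold lower number from compound 2 to compound 3 (0.22 log units; within the scatter) and the two changes read the same.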

Compound 4, half-maximal inhibitory concentration: 7000 nM
Estimate against measurement, compound 4: 4.0-fold (0.60 log units) above; measured number outside the range, below it.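

In this assay, vinyl in place of prop-1-en-1-yl on a carbonyl carbon gives a 6.9-fold lower number from compound 1 to compound 4 (0.84 log units; beyond the scatter), so on the core of compound 1 this change has a clear effect on the read-out. The size of the step does not carry over from one core to the other in this series: the same change on two cores in this assay, a 1.7-fold lower number (0.22 log units; within the scatter) from compound 2 to compound 3 and a 6.9-fold lower number (0.84 log units; beyond the scatter) from compound 1 to compound 4, 4.2-fold (0.62 log units) apart, beyond the scatter of two such steps. For the compounds shown here, only two pairs are available, the step lies beyond the scatter on just one of them, and the two cores differ in more than one place, so nothing here shows which structural difference between the cores goes with the larger step.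

The compounds shown leave open whether the hydroxymethyl group or the ethyl ester, taken alone on an otherwise unchanged core, goes with the size of the step. Going by these compounds, it is also open how the same change reads on a core carrying a carboxylic acid or a primary amide at that point.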